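The source may hold more compounds than are shown below. What is called first, only, known or untested is meant among the compounds shown, and "the series" means these compounds.

Compound 1, `O=c1[nH]c2ccccc2cc1-c1nc2cc([N+](=O)[O-])ccc2[nH]1`, gives > 100000 nM in an ADME assay on L02 cells (Homo sapiens) for cytotoxicity, read by MTT assay, with a stated time of 48 h (on this read-out lower numbers stand for stronger inhibition and higher numbers for weaker inhibition), which is a limit of the assay rather than a number.
Compound 2, `COc1ccc2[nH]c(=O)c(-c3nc4cc(Cl)ccc4[nH]3)cc2c1`, gives > 100000 nM in this assay, again a limit rather than a number.

Compound 2 therefore stands at the ceiling of what this assay reports. Compound 1 stands at the same place, so both values sit together at the limit of > 100000 nM in this assay, at which 2 of the 2 values shown sit, and on these numbers nothing separates the two.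

Compound 3, `O=c1[nH]c2ccccc2cc1-c1nc2cc(Cl)ccc2[nH]1`, has not yet been measured. It arises from compound 2 by hydrogen in place of methoxy on an aromatic carbon; in words, hydrogen in place of methoxy on an aromatic carbon. Going by the values given here, no measured pair shows this particular change, so its effect in this assay has to be judged from the two limits alone. Since both measured compounds sit at the limit, removing the methoxy group is expected to leave compound 3 in the same region, with no step beyond the scatter in either direction. The expected step is thus a number no higher from compound 2 to compound 3 (the limit leaves the size open), essentially none. Compound 3 is estimated at 100000 nM, most likely reported once more only as a limit, with a plausible range from 30000 nM to 300000 nM.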

Compound 3, half-maximal inhibitory concentration: > 100000 nM
Compound 3 gave a limit, no number; the forecaster's own chance of this, stated with the estimate: 85%; the middle value lies on the limit itself.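

No step can be read from compound 2 or from compound 1 to compound 3, since all three compounds sit at the same limit of this assay: the limit of > 100000 nM in this assay, at which 3 of the 3 values shown sit. Going by these compounds, how far each compound lies past that limit, and whether hydrogen in place of methoxy or chloro in place of nitro changes anything in this assay, stays open.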